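Dimethylamino for azetidinyl on a pyridinol core

The source may report more compounds than this note shows. Statements on the series, on what has been measured and on what is new or still open speak of the compounds shown alone.

Measured compounds:
compound 1 `CCCCCCCCCCCCCCCCc1c(C)c(N(C)C)nc(C)c1O`: 11%
compound 2 `CCCCCCCCCCCCCCCCc1nc(N2CCC2)c(C)c(C)c1O`: 13%

In a functional assay on cells (Lymphocyte, Homo sapiens), read by trypan blue exclusion, with a stated time of 16 h, tested at 0.1 uM (a lower number here means a weaker effect, a higher number a stronger effect of the compound at the concentration tested), compound 2 gives 13%. Compound 1 gives 11%, and the two numbers lie within the scatter of each other, so compound 2 stands at a weak effect alongside compound 1. Compound 3 `CCCCCCCCCCCCCCCCc1nc(N(C)C)c(C)c(C)c1O` carries the change (dimethylamino in place of azetidin-1-yl on an aromatic carbon). Compound 1 also carries a dimethylamino group and shows a weak effect, so no step beyond the scatter is expected from compound 2 to compound 3, with a number 1 percentage points lower from compound 2 to compound 3 (within the scatter). In this assay compound 3 is therefore estimated at 12%, ranging from 4% to 22%.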

Compound 3, a percentage reported as activity, at one concentration (the size of the read-out at that concentration, not a potency): 29%
Estimate against measurement, compound 3: 17 percentage points below; the whole stated range lies below it.
By their numbers in this assay, from the lowest: compounds 1 and 2 (each within the scatter of the next); then compound 3.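

In this assay the change of azetidin-1-yl to dimethylamino on the aromatic carbon next to the ring nitrogen gives a number 16 percentage points higher from compound 2 to compound 3 (beyond the scatter) and so shows that this position responds to the choice of amine. Among these compounds, the ring-opened group with one heavy atom fewer is the better of the two here, a difference the earlier compounds could not reveal. No measurement shown accounts for this step. Still open, as far as these compounds go, is where a pyrrolidin-1-yl or diethylamino group would fall at this position. Also open, from the compounds shown here alone, is whether the step would persist with a shorter alkyl chain on the shared core.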